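A few compounds are considered here, and "the series" means these few. Any claim that something is new, unique, unknown or untested is made for them only; others in the source may bear on it.

Values in a functional assay on DU-145 cells (Homo sapiens) for cytotoxicity, read by trypan blue exclusion, with a stated time of 96 h; a lower number here means a stronger inhibitor, a higher number a weaker inhibitor:
Compound 1 `COc1cc(OC)c(/C=C/S(=O)(=O)Nc2ccc(OC)c([N+](=O)[O-])c2)c(OC)c1`: 2500 nM
Compound 2 `COc1cc(OC)c(/C=C/S(=O)(=O)Nc2ccc(OC)c(N)c2)c(OC)c1`: 5 nM
Compound 3 `COc1ccc(NS(=O)(=O)/C=C/c2c(OC)cc(OCCCC(=O)O)cc2OC)cc1[N+](=O)[O-]`: 100000 nM

Compound 3 has the highest number of the three, and its steps to both others lie beyond the scatter, so it is the weakest inhibitor in this small set. Compound 4 `COc1ccc(NS(=O)(=O)/C=C/c2c(OC)cc(OCCCC(=O)O)cc2OC)cc1N` has not yet been measured. It differs from compound 3 in one place: amino in place of nitro on an aromatic carbon.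

For the measured compounds named here, two measured steps bear on this change. The same exchange has been measured once, as a 500-fold lower number from compound 1 to compound 2 (2.70 log units; beyond the scatter), and that step was large. The other step, a 40-fold higher number from compound 1 to compound 3 (1.60 log units; beyond the scatter), was also large and introduces the 2-carboxyethyl group that compound 4 retains. Going by the values given here, no measured pair shows the nitro-to-amino exchange with that group present, so its size may not carry over in full. A large step towards a lower number is nevertheless expected in this assay, of roughly the size seen for compound 2, though with wide uncertainty. The expected change is a 330-fold lower number from compound 3 to compound 4 (2.52 log units; beyond the scatter). For compound 4 the estimated value is 300 nM, with an expected range from 30 nM to 5000 nM.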

Compound 4, half-maximal inhibitory concentration: 10000 nM
Compound 4: the middle estimate sits 33-fold (1.52 log units) below what was measured, and the stated range ends below it.
By their numbers in this assay, from the lowest: compound 2; then compound 1; then compound 4; then compound 3.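

In this assay, the exchange of nitro for amino, on the aromatic carbon ortho to a methoxy group, still lowers the number when the 2-carboxyethyl group is present, but only by a 10-fold lower number from compound 3 to compound 4 (1.00 log units; beyond the scatter), and the size of this step therefore depends on the core that carries it: the same change on two cores in this assay, a 500-fold lower number (2.70 log units; beyond the scatter) from compound 1 to compound 2 and a 10-fold lower number (1.00 log units; beyond the scatter) from compound 3 to compound 4, 50-fold (1.70 log units) apart, beyond the scatter of two such steps

Read the other way, the 2-carboxyethyl group now proves far more costly where amino is present, with a 2000-fold higher number from compound 2 to compound 4 (3.30 log units; beyond the scatter), than where nitro is present: the same change on two cores in this assay, a 40-fold higher number (1.60 log units; beyond the scatter) from compound 1 to compound 3 and a 2000-fold higher number (3.30 log units; beyond the scatter) from compound 2 to compound 4, 50-fold (1.70 log units) apart, beyond the scatter of two such steps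

The two changes therefore do not add up across these four compounds, and neither can be treated as a fixed contribution on the shared core.

What the compounds shown leave open is whether the higher numbers belong to the carboxylic acid at the end of the chain or to the longer chain itself. A methyl ester or a primary amide on the same chain, or a carboxylic acid on a shorter chain, each paired with amino and with nitro, would be needed to separate the two.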